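From Phenyl Ester to Diethyl Amide: Expected Lipophilicity

The compounds below may be only part of what the source reports. "The series", "measured", "known", "first", "only" and "open" are said of these compounds alone.

Three compounds have been measured in a physicochemical assay for lipophilicity; on this read-out lower numbers stand for lower lipophilicity and higher numbers for higher lipophilicity:

compound 1 `CC(/C=C/CC(C)CCCC(C)C)=C\C(=O)Oc1ccccc1` gives 7.67
compound 2 `CCC(C)OC(=O)/C=C(C)/C=C/CC(C)CCCC(C)(C)OC` gives 6.49
compound 3 `CCSC(=O)/C=C(C)/C=C/CC(C)CCCC(C)(C)OC` gives 6.78

Compound 1 stands highest of the three numbers in this assay. Its nearest neighbour is compound 3, whose number is lower by a margin beyond the scatter, and compound 2 lies further still below it. Among the compounds with values here, the one single-point step that has been measured, a number 0.29 log units higher from compound 2 to compound 3 (within the scatter), is within the scatter.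

The unmeasured compound 4 `CCN(CC)C(=O)/C=C(C)/C=C/CC(C)CCCC(C)C` differs from compound 1 in one place: diethylamino in place of phenoxy on a carbonyl carbon. This change is not covered by any measured step. Within the data shown here, the only measured step swaps one group on a carbonyl carbon for another and stays within the scatter, but it exchanges two quite different groups from the ones involved here, so it gives no direct guide. The values of compound 1 and compound 2, which also carry different groups on the carbonyl carbon, show that such a replacement can move the number well beyond the scatter.

On that basis, a downward step is expected, a number 1.77 log units lower from compound 1 to compound 4 (beyond the scatter), and compound 4 is estimated at 5.9, with a range from 5.2 to 6.6.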

Compound 4, partition coefficient: 6.02
Estimate against measurement, compound 4: 0.12 log units below, within the range that was stated.
By their numbers in this assay, from the lowest: compound 4; then compounds 2 and 3 (each within the scatter of the next); then compound 1.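

In this assay, within the data shown here, diethylamino in place of phenoxy on a carbonyl carbon gives a number 1.65 log units lower from compound 1 to compound 4 (beyond the scatter) and so shows that a single replacement at this place can produce a large step, whereas the only earlier single-place step (a number 0.29 log units higher from compound 2 to compound 3 (within the scatter)) stayed within the scatter. The phenoxy group that leaves carries a six-membered aromatic ring of carbon only and the diethylamino group that enters has no ring, but this one pair cannot separate the loss of that ring from the arrival of the nitrogen. No measurement available here accounts for the size of this step.

The compounds shown leave open how the number follows the size of the amine, for instance with dimethylamino or dipropylamino on the same carbonyl carbon. They also leave open how much of the step would remain with ethoxy in place of phenoxy, a comparison that would separate the removal of the ring from the introduction of the nitrogen.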